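From phenoxy to nitro: what one measured step suggests

The source may report more compounds than this note shows. Statements on the series, on what has been measured and on what is new or still open speak of the compounds shown alone.

Measured in a functional assay on Jurkat cells (Homo sapiens); a higher number here means a weaker inhibitor, a lower number a stronger inhibitor:
- Compound 1 `CC(C)[C@H](NC(=O)COc1cccc2ccccc12)C(=O)N[C@@H](CC(=O)O)C(=O)COc1ccc(C(F)(F)F)cc1`: > 100000 nM
- Compound 2 `CC(C)[C@H](NC(=O)COc1cccc2ccccc12)C(=O)N[C@@H](CC(=O)O)C(=O)COc1ccc(Oc2ccccc2)cc1`: 12700 nM

The entry for compound 1, > 100000 nM, is a limit and not a number. Among the compounds with values here, compound 2, at 12700 nM, therefore holds the only actual number so far. Compound 3 `CC(C)[C@H](NC(=O)COc1cccc2ccccc12)C(=O)N[C@@H](CC(=O)O)C(=O)COc1ccc([N+](=O)[O-])cc1` carries nitro in place of phenoxy on an aromatic carbon, para to a large group: nitro in place of phenoxy on an aromatic carbon.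

Within the data shown here, one measured step bears on this change: an at least 7.8-fold lower number from compound 1 to compound 2 (0.89 log units; beyond the scatter), with phenoxy in place of trifluoromethyl on an aromatic carbon. Going by these compounds, its full size stays open because of the limit of > 100000 nM in this assay, at which 1 of the 2 values shown sits. On these data alone, compound 3 also gives up phenoxy, so a move the opposite way, to a higher number in this assay, is expected, though nitro itself is untested. The expected step is a 3.9-fold higher number from compound 2 to compound 3 (0.60 log units; beyond the scatter). For compound 3 the estimated value is 50000 nM, with an expected range of 15000 nM to 150000 nM.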

Compound 3, half-maximal inhibitory concentration: > 100000 nM
Compound 3 ended at the assay's limit; the forecaster's own chance of this, stated with the estimate: 40%; middle value at least 2.0-fold (0.30 log units) away from the limit.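

In this assay compound 3 gives > 100000 nM as its entry, which is a limit and not a number. The result shows that the change away from phenoxy on this aromatic carbon costs activity with a second replacing group as well: the assay records an at least 7.8-fold higher number from compound 2 to compound 3 (0.89 log units; beyond the scatter) for nitro in place of phenoxy, so among the three compounds shown only compound 2 reaches a measured number. Trifluoromethyl and nitro cannot be ranked against each other, and the step between compound 1 and compound 3 cannot be read, because both entries stop at the same limit: the limit of > 100000 nM in this assay, at which 2 of the 3 values shown sit.

Whether the phenoxy ring or its oxygen matters here remains open, since a methoxy, a benzyl or a plain phenyl group in this place is not among the compounds shown. Also open, going by these compounds, is whether an amine or a carboxylic acid here would give a measurable number.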